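Swapping the Aryl Group on Two Related Cores

The source may hold more compounds than are shown below. What is called first, only, known or untested is meant among the compounds shown, and "the series" means these compounds.

Compound 1 `COc1ccc(/C=C2\S/C(=N\c3csc(-c4ccc(Cl)cc4)c3)NC2=O)cc1` gives 28100 nM in a functional assay on SW-620 cells (Homo sapiens) for cytotoxicity, read by MTT assay, with a stated time of 72 h; a lower number here means a stronger inhibitor, a higher number a weaker inhibitor.
Compound 2 `O=C1N/C(=N/c2csc(-c3ccc(Cl)cc3)c2)S/C1=C\c1ccc2ccccc2c1` gives > 50000 nM in this assay, which is a limit of the assay and not a number.
Compound 3 `COc1ccc(/C=C2\S/C(=N\c3nc(-c4ccc(Cl)cc4)cs3)NC2=O)cc1` gives 50 nM in this assay.

Compound 1 and compound 3 differ in their cores, and that difference between the two cores is not broken down here. On the core of compound 1, the change is naphthalen-2-yl in place of 4-methoxyphenyl on a double-bonded chain carbon bound to a double-bonded ring carbon. The step it produced is an at least 1.7-fold higher number from compound 1 to compound 2 (0.25 log units; that floor lies within the scatter); since the value of compound 2 is only a limit, the true size of that step is not known, and one of the three values shown sits at the limit of > 50000 nM in this assay, at which 1 of the 3 values shown sits.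

Compound 4 `O=C1N/C(=N/c2nc(-c3ccc(Cl)cc3)cs2)S/C1=C\c1ccc2ccccc2c1` is not yet measured in this assay. It carries the same change on the core of compound 3: naphthalen-2-yl in place of 4-methoxyphenyl on a double-bonded chain carbon bound to a double-bonded ring carbon. The place is the same in both pairs, so this is the same change, now made on a much stronger starting point, compound 3 with its 50 nM.

For compound 4 the step from compound 3 is expected to be a 6.0-fold higher number from compound 3 to compound 4 (0.78 log units; beyond the scatter), resting on the direction seen from compound 1 to compound 2 and on the fact that only a floor for that step is known. Compound 4 is therefore estimated at 300 nM, with a range from 60 nM to 3000 nM.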

Compound 4, half-maximal inhibitory concentration: 20300 nM
Compound 4: middle estimate off by 68-fold (1.83 log units), on the low side, and the stated range ends below it.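

In this assay, putting naphthalen-2-yl in place of 4-methoxyphenyl on a double-bonded chain carbon bound to a double-bonded ring carbon gives a 410-fold higher number from compound 3 to compound 4 (2.61 log units; beyond the scatter) on the core of compound 3, so the strong value of that core does not survive this change. Compound 2 gives > 50000 nM in this assay, which is a limit of the assay and not a number. The pairs therefore show a higher number on the core of compound 3 but cannot establish whether the change has the same size on both cores, and two pairs give no rule for the wider series: the same change on two cores in this assay, an at least 1.7-fold higher number (0.25 log units; that floor lies within the scatter) from compound 1 to compound 2 and a 410-fold higher number (2.61 log units; beyond the scatter) from compound 3 to compound 4; the limit leaves it open whether they differ.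

The compounds shown leave open whether 4-methoxyphenyl is itself especially favourable at this place, since only naphthalen-2-yl stands against it, and how a plain phenyl, a phenyl bearing a hydroxyl group or a phenyl bearing a dimethylamino group would read on either core. They also leave open how far the result extends beyond this one cell assay, and whether a group other than the 4-chlorophenyl shared by all four compounds would alter the size of the step.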